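A few compounds are considered here, and "the series" means these few. Any claim that something is new, unique, unknown or untested is made for them only; others in the source may bear on it.

Measured in a functional assay on MDA-MB-231 cells (Homo sapiens) for antiproliferative activity, read by XTT assay, with a stated time of 48 h; a lower number here means a stronger inhibitor, a higher number a weaker inhibitor:

- Compound 1 `CC(=O)OC[C@H]1O[C@@H](n2cc(CN(c3ccc(Cl)cc3)S(=O)(=O)c3ccccc3)nn2)[C@H](OC(C)=O)[C@@H]1OC(C)=O`: 250000 nM
- Compound 2 `CS(=O)(=O)N(Cc1cn([C@@H]2O[C@H](CO)[C@@H](O)[C@H](O)[C@H]2O)nn1)c1ccc(C#N)cc1`: 185000 nM
- Compound 3 `CS(=O)(=O)N(Cc1cn([C@H]2O[C@H](CO)[C@@H](O[C@@H]3O[C@H](CO)[C@H](O)[C@H](O)[C@H]3O)[C@H](O)[C@H]2O)nn1)c1ccc(C#N)cc1`: 250000 nM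

Compound 3 reads 250000 nM, the same number as compound 1 at the digits given, and these two share the highest value of the set. Compound 2, at 185000 nM, lies within the usual scatter of both, so these numbers do not separate the three compounds.

The next molecule is compound 4 `CS(=O)(=O)N(Cc1cn([C@@H]2O[C@H](CO)[C@@H](O[C@H]3O[C@H](CO)[C@@H](O)[C@H](O)[C@H]3O)[C@H](O)[C@H]2O)nn1)c1ccc(C#N)cc1`. Compared with compound 3, (the two compounds have the same atoms and bonds and differ only in configuration as drawn: 3 of 10 stereo elements differ; a stereocentre at a saturated ring carbon is drawn S in compound 3 and R in compound 4; a stereocentre at a saturated ring carbon is drawn S in compound 3 and R in compound 4; a stereocentre at a saturated ring carbon is drawn R in compound 3 and S in compound 4). The two compounds have the same atoms and bonds, so nothing leaves and nothing enters. They differ only in configuration as drawn, which means the spatial arrangement at those saturated ring carbons.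

Among the measured compounds shown here, no measured pair here isolates a change of this kind, so there is no direct precedent for its size. For the measured compounds named here, the only guide is that compound 2 at 185000 nM and compound 3 at 250000 nM sit within the scatter of each other despite their different structures. The expected change is a 1.1-fold lower number from compound 3 to compound 4 (0.06 log units; within the scatter), which would be no shift beyond the scatter. For compound 4 the estimated value is 220000 nM, with an expected range from 120000 nM to 350000 nM.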

Compound 4, half-maximal inhibitory concentration: 250000 nM
Compound 4: middle estimate off by 1.1-fold (0.06 log units), on the low side; measured number inside the range.
By their numbers in this assay, from the lowest: compounds 2, 1, 3 and 4 (each within the scatter of the next).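

In this assay, among the compounds shown here, redrawing the three ring carbons gives no change at the digits printed from compound 3 to compound 4 (within the scatter), so this is the first pair in the set to test a change of spatial arrangement with the atoms and bonds held fixed. Attaching the 3,4,5-trihydroxy-6-(hydroxymethyl)oxan-2-yl group in place of hydrogen on an oxygen on a saturated carbon gives a 1.4-fold higher number from compound 2 to compound 4 (0.13 log units; within the scatter), so adding this group, in the configuration of compound 4, also leaves the reading within the scatter. At this position, then, one swapped set of three stereocentres has no measurable effect on the reading, and the comparison is clean, though it rests on a single pair: the fact that compounds 3 and 4 differ only in the configuration as drawn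

On these data alone, what remains open is whether any change at this oxygen can move the number out of the scatter, since compound 2 and compound 4 differ by a whole added sugar without doing so. An amine or a carboxylic acid in place of the added sugar, or a longer chain carrying either group, might answer this, and the compounds shown give no hint of which way such a change would go.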